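Swapping the carboxyfuran for a pyrazole on the chlorobenzyl arm

A few compounds are considered here, and "the series" means these few. Any claim that something is new, unique, unknown or untested is made for them only; others in the source may bear on it.

Of the compounds shown here, three sharing one core have been measured in an assay on isolated protein for inhibition of ubiquitin carboxyl-terminal hydrolase 7 (Homo sapiens), with stated times of 30 min and 2 h; on this read-out higher numbers stand for weaker inhibition and lower numbers for stronger inhibition. Compound 1 `Cn1nc2c(=O)n(CC3(O)CCN(Cc4ccc(C5=CCCC5)cc4Cl)CC3)cnc2c1-c1ccc(CN)cc1` carries a cyclopent-1-en-1-yl group and gives 76.9 nM. Compound 2 `Cn1nc2c(=O)n(CC3(O)CCN(Cc4ccc(-c5ccc[nH]5)cc4Cl)CC3)cnc2c1-c1ccc(CN)cc1` carries a 1H-pyrrol-2-yl group in its place and gives 193 nM. Compound 3 `Cn1nc2c(=O)n(CC3(O)CCN(Cc4ccc(-c5ccc(C(=O)O)o5)cc4Cl)CC3)cnc2c1-c1ccc(CN)cc1` carries a 5-carboxyfuran-2-yl group and gives 753 nM, the highest number of the three: the measured step is a 3.9-fold higher number from compound 2 to compound 3 (0.59 log units; beyond the scatter), and a 9.8-fold higher number from compound 1 to compound 3 (0.99 log units; beyond the scatter).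

Compound 4 `Cn1nc2c(=O)n(CC3(O)CCN(Cc4ccc(-n5cccn5)cc4Cl)CC3)cnc2c1-c1ccc(CN)cc1` differs from compound 3 in one place: 1H-pyrazol-1-yl in place of 5-carboxyfuran-2-yl on an aromatic carbon.

Within the data shown here, two measured steps bear on this. The step of a 2.5-fold higher number from compound 1 to compound 2 (0.40 log units; beyond the scatter) shows that a five-membered aromatic ring with one hetero atom sits only modestly behind the cyclopentenyl group. Among the measured compounds shown here, the step of a 3.9-fold higher number from compound 2 to compound 3 (0.59 log units; beyond the scatter) shows that the 5-carboxyfuran-2-yl group is the one that carries the number furthest up. Compound 4 removes that group and brings in a ring without a hydrogen-bond donor, so the expectation for compound 4 in this assay is a return toward the number of compound 2, estimated as a 3.8-fold lower number from compound 3 to compound 4 (0.58 log units; beyond the scatter). Compound 4 is therefore expected to give about 200 nM, with a likely range from 80 nM to 500 nM.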

Compound 4, half-maximal inhibitory concentration: 233 nM
Compound 4: middle estimate off by 1.2-fold (0.07 log units), on the low side, within the range that was stated.
By their numbers in this assay, from the lowest: compound 1; then compounds 2 and 4 (each within the scatter of the next); then compound 3.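

In this assay the step of a 3.2-fold lower number from compound 3 to compound 4 (0.51 log units; beyond the scatter) is matched by the step of a 1.2-fold higher number from compound 2 to compound 4 (0.08 log units; within the scatter) and so brings the number back level with that of the pyrrole, even though the 1H-pyrazol-1-yl group has no hydrogen-bond donor and adds a second hetero atom to the ring. Among these compounds, then, a five-membered aromatic ring at this place, para to a large group, does not depend on a hydrogen-bond donor to reach this level, yet the step of a 3.0-fold higher number from compound 1 to compound 4 (0.48 log units; beyond the scatter) shows that neither aromatic ring without a carboxyl group matches the cyclopent-1-en-1-yl group of compound 1, which keeps the lowest number of the four. Nothing available here gives a measured reason for any of these differences.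

The compounds shown leave open whether the higher number of compound 3 goes with its carboxylic acid or with its furan ring, a question that a plain furan-2-yl group or a pyrazole carrying a carboxylic acid could settle. On these data alone, it also remains open how a fully saturated cyclopentyl ring, or a pyrazole carrying an amine, would compare at this place.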